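This account rests on a few compounds, and the source may have more. Where it says the series, first, only, none or still open, it means among the compounds named here.

Compound 1 `CCOC(=O)C1(Cc2ccccc2)CN(c2ccccc2)Cc2nnn(Cc3ccc(OC)cc3)c21` and compound 2 `CCOC(=O)C1(Cc2ccccc2)CN(c2ccccc2)Cc2nnn(Cc3c(F)cccc3Cl)c21` share one core and differ only in the arm on the saturated chain carbon. In an ADME assay on HEL cells (Homo sapiens) for cytotoxicity, read by microscopy, with a stated time of 3 days (a higher number here means that more compound is tolerated, a lower number that less compound is tolerated), compound 1 reaches only the limit > 100000 nM. In this assay compound 2 likewise stops at the limit > 100000 nM. The step that the two limits leave unreadable from compound 1 to compound 2 stays unreadable in size since (the limit of > 100000 nM in this assay, at which 2 of the 2 values shown sit). Compound 3 `CCCCCCCCn1nnc2c1C(Cc1ccccc1)(C(=O)OCC)CN(c1ccccc1)C2` carries the change (heptyl in place of 2-chloro-6-fluorophenyl on a saturated chain carbon bound to an aromatic nitrogen), which cut one bond further out reads 2-chloro-6-fluorobenzyl to octyl. Within the data shown here, no measured step guides this change beyond both earlier values sitting at the limit. Compound 3 is expected to sit again at the limit in this assay, with an estimated 100000 nM within 30000 nM to 300000 nM. The expected step of a number no higher from compound 2 to compound 3 (the limit leaves the size open) is none beyond the scatter.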

Compound 3, minimum cytotoxic concentration: >= 20000 nM
Compound 3: no number, only a limit; the forecaster's own chance of this, stated with the estimate: 75%; the middle value is on the limit's open side.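

Among these compounds, compound 1, compound 2 and compound 3 all give only limits in this assay, and no step among them can be read. The compounds shown leave open at what concentration each becomes toxic to the cells, and whether changing the arm shifts that concentration.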